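The compounds below may be only part of what the source reports. "The series", "measured", "known", "first", "only" and "open" are said of these compounds alone.

Measured in an ADME assay on cells (Peritoneal macrophage, Mus musculus, strain Swiss) for cytotoxicity, with a stated time of 24 h; a higher number here means that more compound is tolerated, a lower number that less compound is tolerated:
Compound 1 `O=C1C(Br)=C(Br)C(=O)c2c(I)cccc21` gives 11800 nM
Compound 2 `O=C1C(Cl)=C(Cl)C(=O)c2c(I)cccc21` gives 27800 nM
Compound 3 `O=C1C=CC(=O)C(I)=C1` gives 86000 nM

Compound 3 stands highest of the three, and the gaps down to compound 2 and to compound 1 both lie beyond the scatter. Compound 4 `O=C1C=CC(=O)C(Br)=C1` has not yet been measured. It carries bromo in place of iodo on a double-bonded ring carbon and otherwise matches compound 3. Among the compounds with values here, no pair of measured compounds shows this change on its own. With compound 3 at 86000 nM as the only anchor, no change beyond the scatter is expected in this assay for this swap. The estimate is a 1.2-fold lower number from compound 3 to compound 4 (0.09 log units; within the scatter) and is expected to be small. Compound 4 is expected at 70000 nM (range 25000 nM to 170000 nM).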

Compound 4, concentration lethal to 50% of the cells: 34400 nM
Beside the measured number, compound 4's estimate is 2.0-fold (0.31 log units) above it; measured number inside the range.
By their numbers in this assay, from the lowest: compound 1; then compounds 2 and 4 (each within the scatter of the next); then compound 3.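

In this assay the halogen on this double-bonded ring carbon proves to count: bromo in place of iodo gives a 2.5-fold lower number from compound 3 to compound 4 (0.40 log units; beyond the scatter) as a modest step, with less compound tolerated. Within the data shown here, the earlier compounds offered no single-place step, so this is the first reading of any such change. Nothing at hand bears on why the number falls. Going by these compounds, whether an amine, a methoxy group or a methyl on this carbon would stand above or below compound 3 remains open. So does whether this swap would act alike on another core.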